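Swapping a phenyl ester

This account rests on a few compounds, and the source may have more. Where it says the series, first, only, none or still open, it means among the compounds named here.

Measured in an ADME assay on a cell-free system (plasma, Homo sapiens) for metabolic stability, read by LC-MS; a lower number here means that the compound disappears faster, a higher number that the compound lasts longer:
Compound 1 `NCc1ccc(C(=O)Nc2ccncc2F)cc1-c1cccc(C(=O)Oc2ccccc2)c1` gives 0.117 h
Compound 2 `NCc1ccc(C(=O)Nc2ccncc2)cc1-c1cccc(C(=O)OCC2CCCCC2)c1` gives 1.65 h

Compound 1 has the lower of these two numbers, and its gap to compound 2 lies beyond the usual scatter of repeated measurements. Compound 3 `NCc1ccc(C(=O)Nc2ccncc2F)cc1-c1cccc(C(=O)OCC2CC2)c1` has not yet been measured. It carries cyclopropylmethyl in place of phenyl on an oxygen next to a carbonyl group.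

Within the data shown here, no measured pair shows this change on its own, so any expectation is tentative and rests on just two numbers. Of the two measured compounds, compound 2 has the higher number at 1.65 h and the estimate leans towards it. A clear rise is expected, and the estimated change is a 10-fold higher number from compound 1 to compound 3 (1.01 log units; beyond the scatter). The estimate for compound 3 is 1.2 h, with an expected range from 0.35 h to 4 h.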

Compound 3, half-life: 0.3 h
The estimate for compound 3 lay 4.0-fold (0.60 log units) above the measured number; measured number below the stated range.
By their numbers in this assay, from the lowest: compound 1; then compound 3; then compound 2.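

In this assay, cyclopropylmethyl in place of phenyl on an oxygen next to a carbonyl group gives a 2.6-fold higher number from compound 1 to compound 3 (0.41 log units; beyond the scatter), a modest step but one beyond the usual scatter. Among these compounds, this is the first pair that differs only at this position, so it shows that this one change, with the rest of the compound held the same, is enough to move the half-life. Compound 1 and compound 2 differ in more than one place and could not show this. No measurement here gives a reason for the size of the step.

From the compounds shown here alone, it remains open whether the rise is specific to cyclopropylmethyl or would also appear with a small open chain such as ethyl or a longer chain on the same oxygen. An amide in place of the ester is also untested among these compounds.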